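Estimating Compound 4 from Compounds 2 and 3

The source may hold more compounds than are shown below. What is called first, only, known or untested is meant among the compounds shown, and "the series" means these compounds.

Compound 1 `Cc1cccc(NC(=O)CSC(=S)N[C@H]2CCOC2=O)c1C`: in a functional assay on MCF7 cells (Homo sapiens) for cytotoxicity, read by MTT assay, with a stated time of 72 h (on this read-out higher numbers stand for weaker inhibition and lower numbers for stronger inhibition), compound 1 gives > 128000 nM, a limit of the assay.
Compound 2 `O=C(CSC(=S)N[C@H]1CCOC1=O)Nc1cccc(Cl)c1`: compound 2 gives 46600 nM.
Compound 3 `O=C(CSC(=S)N[C@H]1CCOC1=O)Nc1cccc([N+](=O)[O-])c1`: compound 3 gives 5460 nM.

Compound 2 has the highest of the two numbers shown; its nearest neighbour is compound 3, reached by an 8.5-fold lower number from compound 2 to compound 3 (0.93 log units; beyond the scatter), a modest step. Compound 4 `O=C(CSC(=S)N[C@H]1CCOC1=O)Nc1ccc(O)cc1` differs from compound 2 by 4-hydroxyphenyl in place of 3-chlorophenyl on an amide-type nitrogen. Among the compounds with values here, no measured step exchanges a chloro for a hydroxyl, so the single measured step bears only loosely on this change, and compound 1 sits at the limit of > 128000 nM in this assay, at which 1 of the 3 values shown sits. Compound 4 is therefore expected to give 80000 nM, with a range from 20000 nM to 200000 nM. This estimate would mean a 1.7-fold higher number from compound 2 to compound 4 (0.23 log units; within the scatter), a step expected within the scatter, with a real chance that only a limit is reported.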

Compound 4, half-maximal inhibitory concentration: > 128000 nM
Compound 4: no number, only a limit; the forecaster's own chance of this, stated with the estimate: 35%; at least 1.6-fold (0.20 log units) between middle value and limit.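

In this assay, 4-hydroxyphenyl in place of 3-chlorophenyl on the amide-type nitrogen gives an at least 2.7-fold higher number from compound 2 to compound 4 (0.43 log units; beyond the scatter). This runs opposite to an 8.5-fold lower number from compound 2 to compound 3 (0.93 log units; beyond the scatter), so changes at this place can move the number either way. Compound 4 gives only a limit, so the full size of its step cannot be read: the limit of > 128000 nM in this assay, at which 2 of the 4 values shown sit.

The change replaces chloro with hydroxyl and also moves the group, and the compounds shown do not separate these two differences. As far as these compounds go, whether an amine or a carboxylic acid on the phenyl ring would follow compound 3 or compound 4 stays open.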